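The source may hold more compounds than are shown below. What is called first, only, known or untested is meant among the compounds shown, and "the series" means these compounds.

Values measured in a functional assay on PC-3 cells (Homo sapiens) for cytotoxicity, read by MTT assay, with a stated time of 48 h (a higher number here means a weaker inhibitor, a lower number a stronger inhibitor), are as follows.
- Compound 1 `COc1ccc(OC)c(/C=C/C(=O)/C=C/c2cc3ccccc3nc2Oc2ccc(Br)cc2)c1` gives > 10000 nM as a limit
- Compound 2 `COc1ccc(/C=C/C(=O)/C=C/c2cc3ccccc3nc2Oc2cccc(Cl)c2)c(OC)c1` gives > 10000 nM as a limit

Compound 2 stands at > 10000 nM in this assay, which is a limit of the assay and not a number. Both measured compounds share this position, as the limit of > 10000 nM in this assay, at which 2 of the 2 values shown sit, shows. Neither therefore gives a number from which the size of a structural step could be read.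

Compound 3 `COc1ccc(OC)c(/C=C/C(=O)/C=C/c2cc3ccccc3nc2Oc2cccc(Cl)c2)c1` has not yet been measured. It has the same atoms as compound 2, joined differently: 2,5-dimethoxyphenyl in place of 2,4-dimethoxyphenyl on a double-bonded chain carbon bound to a double-bonded chain carbon. The change places 2,5-dimethoxyphenyl where 2,4-dimethoxyphenyl stood, on a double-bonded chain carbon bound to a double-bonded chain carbon.

With compound 2 held at the limit of > 10000 nM in the assay, no clear gain or loss is expected from this exchange. The expected step that the limit leaves unreadable from compound 2 to compound 3 is no larger than the usual scatter and has no favoured direction. The assay is expected to report a limit again rather than a number. For compound 3 the estimated value is 12000 nM, with an expected range from 4000 nM to 30000 nM.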

Compound 3, half-maximal inhibitory concentration: > 10000 nM
Compound 3: no number, only a limit (the forecaster's own chance of this, stated with the estimate: 75%); the middle value lies beyond the limit too.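

In this assay compound 3 gives > 10000 nM, a limit of the assay and not a number. The steps to compound 3 from compound 1 and from compound 2 therefore cannot be read, as all three compounds sit at the same limit: the limit of > 10000 nM in this assay, at which 3 of the 3 values shown sit. The compounds shown leave open whether either exchange, 2,5-dimethoxyphenyl for 2,4-dimethoxyphenyl or 3-chlorophenyl for 4-bromophenyl, changes the value at all.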